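This account rests on a few compounds, and the source may have more. Where it says the series, first, only, none or still open, it means among the compounds named here.

Of the compounds shown here, two have been measured in an assay on cells for inhibition of high affinity 3',5'-cyclic-AMP phosphodiesterase 7A (Homo sapiens), read by scintillation counting and cAMP accumulation, with a stated time of 30 min; a higher number here means a weaker inhibitor, a lower number a stronger inhibitor. Compound 1 `CCn1c(CC(C)C)nc2ccsc2c1=O` gives 4700 nM. Compound 2 `CCNc1nc2ccsc2c(=O)n1CC` gives 2900 nM. Among the compounds with values here, the one step between them, a 1.6-fold lower number from compound 1 to compound 2 (0.21 log units; within the scatter), puts ethylamino in place of isobutyl on an aromatic carbon and stays within the scatter, so neither compound can be called the stronger inhibitor on this evidence. Compound 2 has the lower of the two numbers, but only by that margin.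

Compound 3 `CCn1c(NC2CCC2)nc2ccsc2c1=O` has not yet been measured. It differs from compound 2 in one place: cyclobutyl in place of ethyl on a nitrogen on an aromatic ring. Within the data shown here, no measured step touches this nitrogen. Among the measured compounds shown here, the single known step, a 1.6-fold lower number from compound 1 to compound 2 (0.21 log units; within the scatter), changed a group on an aromatic carbon and stayed within the scatter, so it offers no direct guidance and only shows that the one alteration tried so far around the shared core moved the number little. The expectation is therefore a step of a 1.2-fold lower number from compound 2 to compound 3 (0.06 log units; within the scatter) for compound 3, not larger than the scatter. Compound 3 is estimated at 2500 nM, within a range from 800 nM to 8000 nM.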

Compound 3, half-maximal inhibitory concentration: 300 nM
Compound 3: middle estimate off by 8.3-fold (0.92 log units), on the high side, outside the stated range (below it).
By their numbers in this assay, from the lowest: compound 3; then compounds 2 and 1 (each within the scatter of the next).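

The nitrogen carrying the ethyl of compound 2 is a place where a change clearly moves the number: in this assay, cyclobutyl in place of ethyl gives a 9.7-fold lower number from compound 2 to compound 3 (0.99 log units; beyond the scatter). The earlier step between compound 1 and compound 2 stayed within the scatter and gave no sign of this, while exchanging the whole group on the aromatic carbon now gives a 16-fold lower number from compound 1 to compound 3 (1.19 log units; beyond the scatter), so what is attached to that carbon can matter a great deal after all. The entering group brings both more carbon and a four-membered non-aromatic ring, and this single change cannot separate those two differences, while no independent measurement accounts for the gain.

Going by these compounds, it remains open whether an open-chain group such as isopropyl or isobutyl on this nitrogen would match cyclobutyl, which would show whether the ring itself counts, and whether a smaller or larger ring, such as cyclopropyl or cyclohexyl, would lower the number further. Also open, on these data alone, is how a hydroxyl group or an amine attached to the cyclobutyl ring would change the number.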